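Shortening the Chain of Compound 1

This account rests on a few compounds, and the source may have more. Where it says the series, first, only, none or still open, it means among the compounds named here.

Compound 1 (`O=C(O)CCCCCNC(=O)c1cc(=O)c2ccccc2o1`) is tested in a functional assay on cells (Mast cell, Rattus norvegicus) for inhibition, with a stated time of 15 min (on this read-out lower numbers stand for an effect already at smaller amounts and higher numbers for an effect only at larger amounts of compound), where compound 1 gives > 18 ug/mL. That figure is a limit of the assay and not a number. The other two measured compounds have different structures and give numbers: compound 2 (`O=C(O)C(c1coc2ccccc2c1=O)c1coc2ccccc2c1=O`) gives 8 ug/mL, and compound 3 (`O=C(NC1CCCCC1)N(C(=O)c1cc2ccccc2c(=O)o1)C1CCCCC1`) gives 8 ug/mL.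

Compound 4 (`O=C(O)CCCNC(=O)c1cc(=O)c2ccccc2o1`) keeps the core of compound 1 and changes only the chain: carboxy in place of 2-carboxyethyl on a saturated chain carbon, three bonds along the chain from an amide-type nitrogen. In words, carboxy stands in place of 2-carboxyethyl on a saturated chain carbon, three bonds along the chain from an amide-type nitrogen.

Among the measured compounds shown here, no two measured compounds differ in just one place, so no measured step shows what such a change does in this assay. With no direction to favour, the estimated step that the limit leaves unreadable from compound 1 to compound 4 is expected to stay within the usual scatter. Compound 4 may also be reported only as a limit. For compound 4 the expected value is 20 ug/mL, with an estimated range of 9 ug/mL to 50 ug/mL.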

Compound 4, concentration for half-maximal effect: > 18 ug/mL
Compound 4 ended at the assay's limit; the forecaster's own chance of this, stated with the estimate: 60%; the middle value is on the limit's open side.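

Compound 1 and compound 4 each give only a limit and not a number in this assay, so no step between them can be read: the limit of > 18 ug/mL in this assay, at which 2 of the 4 values shown sit.

What carboxy in place of 2-carboxyethyl does in this assay remains open in the compounds shown.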